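This account rests on a few compounds, and the source may have more. Where it says the series, first, only, none or still open, it means among the compounds named here.

Measured in a functional assay on A2780 cells (Homo sapiens) for inhibition; on this read-out higher numbers stand for weaker inhibition and lower numbers for stronger inhibition:
- Compound 1 `CCNC(=O)c1noc(-c2cc(C(C)C)c(O)cc2O)c1-c1cc(CN)no1`: "not determined" (no result reported)
- Compound 2 `CCNC(=O)c1noc(-c2cc(C(C)C)c(O)cc2O)c1-c1cc(CNC(C)C)no1`: 38 nM
- Compound 3 `CCNC(=O)c1noc(-c2cc(C(C)C)c(O)cc2O)c1-c1cc(CNC(C)=O)no1`: "not determined" (no result reported)

Compound 3 has no place on the potency scale. No number was reported for it. Compound 1 likewise has no number. That leaves a single measured value in the set, so nothing can be ranked and no trend can be read.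

The next compound to be tested is compound 4 `CCNC(=O)c1noc(-c2cc(C(C)C)c(O)cc2O)c1-c1cc(CN2CCCCC2)no1`. The structural change is piperidin-1-yl in place of acetamido on a saturated chain carbon bound to an aromatic carbon: piperidin-1-yl takes the place of acetamido on a saturated chain carbon bound to an aromatic carbon, and the shared core stays the same.

In this assay, going by the values given here, no step has been measured, and without a number for compound 3 the size and direction of this step cannot be stated. Among the compounds with values here, the only anchor is compound 2 at 38 nM, so a result near that value is the most reasonable expectation, with wide margins. Compound 4 is estimated at 35 nM, with an expected range of 12 nM to 110 nM.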

Compound 4, half-maximal inhibitory concentration: 62 nM
Compound 4: the middle estimate sits 1.8-fold (0.25 log units) below what was measured; measured number inside the range.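

In this assay the swap of isopropylamino for piperidin-1-yl on a saturated chain carbon bound to an aromatic carbon gives a 1.6-fold higher number from compound 2 to compound 4 (0.21 log units; within the scatter) and so lies within the usual scatter of repeated measurements. This second number at the position shows that an open-chain group and one six-membered non-aromatic ring with 1 hetero atom read alike here, although this pair alone cannot show a wider pattern. Nothing at hand explains this result.

Steps involving compound 1 or compound 3 cannot be read, so the acetamido group and the plain amine of compound 1 have no place on this scale. Also open, from the compounds shown here alone, is how a morpholin-4-yl ring or a carboxylic acid at this position would read.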